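Swapping fluoro for methyl on the benzyl ring of compound 3

The source may report more compounds than this note shows. Statements on the series, on what has been measured and on what is new or still open speak of the compounds shown alone.

Compound 3 `Nc1cccc(/C=C2\SC(=O)N(Cc3ccc(F)cc3)C2=O)c1` stands highest of the three numbers in a functional assay on L1210 cells (Mus musculus) for cytotoxicity, read by cell counting, with a stated time of 2 days (a lower number here means a stronger inhibitor, a higher number a weaker inhibitor), where compound 3 gives 142000 nM. Its nearest neighbour is compound 2 `Nc1ccc(/C=C2\SC(=O)N(Cc3ccc(F)cc3)C2=O)cc1`, which in this assay gives 24000 nM; the step of a 5.9-fold higher number from compound 2 to compound 3 (0.77 log units; beyond the scatter) is modest. Compound 1 `C=C(Br)C(=O)Nc1cccc(/C=C2\SC(=O)N(Cc3ccc(F)cc3)C2=O)c1` in this assay gives 680 nM, and the step of a 210-fold higher number from compound 1 to compound 3 (2.32 log units; beyond the scatter) is large. Compound 4 `Cc1ccc(CN2C(=O)S/C(=C\c3cccc(N)c3)C2=O)cc1` differs from compound 3 only in this: methyl in place of fluoro on an aromatic carbon. Neither measured step touches this ring, so no shown step bears on the change, and there is no ground for a step beyond the scatter in either direction. Compound 4 is therefore expected near compound 3, a step of a 1.0-fold lower number from compound 3 to compound 4 (0.01 log units; within the scatter), with an estimated 140000 nM spanning 50000 nM to 400000 nM.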

Compound 4, half-maximal inhibitory concentration: 176000 nM
The estimate for compound 4 lay 1.3-fold (0.10 log units) below the measured number; measured number inside the range.
By their numbers in this assay, from the lowest: compound 1; then compound 2; then compounds 3 and 4 (each within the scatter of the next).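

In this assay the swap from 4-fluorophenyl to 4-methylphenyl gives a 1.2-fold higher number from compound 3 to compound 4 (0.09 log units; within the scatter) and so leaves compound 3 and compound 4 indistinguishable. Going by these compounds alone, this is the first reading on this ring, as the earlier steps concerned only the other aromatic ring and its nitrogen, and here fluoro and methyl read alike. Nothing at hand gives a reason for this match. From the compounds shown here alone, whether a methoxy group or a carboxylic acid at this place would read the same stays open. Also open, going by these compounds, is whether the swap would hold with the (1-bromoethenyl)carbonyl group of compound 1 in place.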